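Swapping tert-butyl for fluoro on a receptor ligand

The source may report more compounds than this note shows. Statements on the series, on what has been measured and on what is new or still open speak of the compounds shown alone.

Compound 1 `CC(C)(C)c1ccc(Oc2ccc3nc(-c4ccc(OCCCN5CCCCC5)cc4)oc3c2)cc1`, in an assay on isolated protein for inhibition of advanced glycosylation end product-specific receptor (Homo sapiens), read by FRET, with stated times of 30 min and 1 h, tested at 4 uM; on this read-out higher numbers stand for more inhibition at the one concentration tested (going by the name of the read-out) and lower numbers for less inhibition: "not active" (no number reported). Compound 2 `CC(C)(C)c1ccc(Oc2ccc3nc(-c4ccc(OCCCN5CC[C@H](N)C5)cc4)oc3c2)cc1`, in this assay: 54.7%.

In this assay compound 1 stands without a number, reported as not active, whereas compound 2 gives 54.7%. For the measured compounds named here, the two differ in their amine, and no step between them is counted here. Compound 3 `Fc1ccc(Oc2ccc3nc(-c4ccc(OCCCN5CCCCC5)cc4)oc3c2)cc1` is the unmeasured analogue of compound 1 with the change (fluoro in place of tert-butyl on an aromatic carbon). Going by the values given here, no measured pair shows this change, so its size and direction cannot be read from the data; the expectation is a small step at most. Compound 3 is estimated to give 15%, within 0% to 45%.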

Compound 3, a percentage reported as inhibition, at one concentration (the size of the read-out at that concentration, not a potency): 30.3%
Compound 3: middle estimate off by 15.3 percentage points, on the low side, within the range that was stated.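

No step can be read from compound 1 to compound 3 in this assay, as compound 1 has no number there. No evidence bears on this result. The compounds shown leave open how large the change from tert-butyl to fluoro is between two numbered compounds.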